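Swapping the Amide Partner on Compound 2

The source may hold more compounds than are shown below. What is called first, only, known or untested is meant among the compounds shown, and "the series" means these compounds.

Of the compounds shown here, three have been measured in a functional assay on cells (Pituitary gland cell) for antagonist activity at Gonadotropin-releasing hormone receptor (Rattus norvegicus); on this read-out lower numbers stand for stronger inhibition and higher numbers for weaker inhibition. Compound 1 `Cc1cc(-c2c(O)nc3cc(Cl)c([N+](=O)[O-])cc3c2OCCC2CCCCN2)cc(C(C)O)c1` gives 63 nM, compound 2 `Cc1cc(C)cc(-c2c(O)nc3cc(Cl)c(NC(=O)c4cnccn4)cc3c2OCCC2CCCCN2)c1` gives 1.8 nM, and compound 3 `O=[N+]([O-])c1cc2c(OCCC3CCCCN3)c(-c3ccccc3)c(O)nc2cc1Cl` gives 410 nM. Compound 2 therefore stands lowest of the three, with compound 1 nearest and compound 3 furthest away. Among the compounds with values here, the only step between two compounds that differ in a single place, a 6.5-fold higher number from compound 1 to compound 3 (0.81 log units; beyond the scatter), concerns a different place on the shared core, an aromatic carbon, and not the position changed here.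

Compound 4 `Cc1cc(C)cc(-c2c(O)nc3cc(Cl)c(NC(=O)Nc4ccccn4)cc3c2OCCC2CCCCN2)c1` differs from compound 2 by (pyridin-2-yl)amino in place of pyrazin-2-yl on a carbonyl carbon. Within the data shown here, no measured step bears on this change at the carbonyl carbon, so the expectation rests only on compound 2 already standing lowest and on the rest of the molecule being kept unchanged. A step of modest size, or none beyond the scatter, is expected, and the estimate leans slightly toward a higher number, a 2.2-fold higher number from compound 2 to compound 4 (0.35 log units; beyond the scatter). Compound 4 is thus expected to give 4 nM in this assay, within a range from 1 nM to 20 nM.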

Compound 4, half-maximal inhibitory concentration: 15 nM
Compound 4: the middle estimate sits 3.8-fold (0.57 log units) below what was measured; the range from low to high includes it.
By their numbers in this assay, from the lowest: compound 2; then compound 4; then compound 1; then compound 3.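

In this assay, within the data shown here, putting (pyridin-2-yl)amino in place of pyrazin-2-yl on the carbonyl carbon gives an 8.3-fold higher number from compound 2 to compound 4 (0.92 log units; beyond the scatter) and is the first measured sign that inhibition responds to what sits at this position. The swap alters several things at once: the entering group has one more heavy atom, adds a hydrogen-bond donor and carries one hetero atom fewer in its aromatic ring, so this single step cannot show which of these differences matters. No available evidence gives a reason for the step.

The compounds shown leave open whether the extra amino nitrogen or the change of ring accounts for the difference, which pyridin-2-yl or (pyrazin-2-yl)amino on the same carbonyl carbon could help to separate. Going by these compounds, how a non-aromatic group such as morpholin-4-yl or a simple methyl would fare at this position also remains open.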